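This account rests on a few compounds, and the source may have more. Where it says the series, first, only, none or still open, it means among the compounds named here.

Compound 1, `CC(C)OC(=O)N1CCC(Oc2cccc3c2CCN3c2ccc(S(C)(=O)=O)cc2)CC1`, was examined in a functional assay on CHO-K1 cells for agonist activity at Glucose-dependent insulinotropic receptor (Homo sapiens), read by a luciferase reporter, with a stated time of 5 h (on this read-out lower numbers stand for an effect already at smaller amounts and higher numbers for an effect only at larger amounts of compound), where compound 1 gives 501 nM. Compound 2, `CC(C)OC(=O)N1CCC(Oc2cccc3c2CCN3c2ccc(S(C)(=O)=O)cc2F)CC1`, differs from it only by a fluoro in place of hydrogen on an aromatic carbon; in this assay compound 2 gives 1000 nM, and the step of a 2.0-fold higher number from compound 1 to compound 2 (0.30 log units; within the scatter) stays within the scatter of repeated measurements. Compound 3, `COC(=O)N1CCC(Oc2ncnc3c2CCN3c2ccc(S(C)(=O)=O)cc2F)CC1`, has a different core and a methoxy on its carbonyl carbon; in this assay compound 3 gives 316 nM, the lowest of the three numbers. Its gap to compound 1 lies within the scatter, so these two cannot be ranked, whereas its gap to compound 2 lies beyond it.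

Compound 4, `CSC(=O)N1CCC(Oc2ncnc3c2CCN3c2ccc(S(C)(=O)=O)cc2F)CC1`, is reached from compound 3 by a single change: methylsulfanyl in place of methoxy on a carbonyl carbon. Among the measured compounds shown here, none of the measured steps touches this carbonyl carbon. For the measured compounds named here, the only measured step, from compound 1 to compound 2, exchanges hydrogen for fluoro on an aromatic carbon elsewhere in the molecule, so it offers no direct guidance on replacing methoxy with methylsulfanyl. In the absence of any such precedent, the expectation in this assay is a step no larger than the scatter, a 1.0-fold higher number from compound 3 to compound 4 (0.01 log units; within the scatter). Compound 4 is therefore estimated at 320 nM, with a likely range from 120 nM to 900 nM.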

Compound 4, half-maximal effective concentration: 251 nM
Compound 4: the middle estimate sits 1.3-fold (0.11 log units) above what was measured; the range from low to high includes it.
By their numbers in this assay, from the lowest: compounds 4, 3, 1 and 2 (each within the scatter of the next, the first and the last beyond it).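

In this assay, exchanging methoxy for methylsulfanyl on the carbonyl carbon, whose other neighbour is an amide-type nitrogen in a ring, gives a 1.3-fold lower number from compound 3 to compound 4 (0.10 log units; within the scatter) and so leaves the two compounds indistinguishable. This is the only step shown that touches this carbonyl carbon, and it shows that, on this core, the oxygen of the methoxy can give way to the sulfur of methylsulfanyl without a difference that rises above the scatter; both groups count the same number of heavy atoms, hydrogen-bond donors and hydrogen-bond acceptors. No measurement offered here bears on why the two compounds behave alike.

Still open, from the compounds shown here alone, is how far this tolerance reaches: one exchange cannot say whether a longer chain such as ethylsulfanyl, or an amine such as dimethylamino, on the same carbonyl carbon would keep the number in the same region. Going by these compounds, it also remains unknown whether the same exchange would behave alike on the core of compound 1, which differs from that of compound 3 in more than one place.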